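Adding a Methoxy to Compound 1: What to Expect

The source may report more compounds than this note shows. Statements on the series, on what has been measured and on what is new or still open speak of the compounds shown alone.

Compound 1 `COc1cc(NCc2ccccc2)cc(OC)c1OC` is tested in a functional assay on HCT-116 cells (Homo sapiens) for inhibition, read by MTT assay, with a stated time of 48 h; a lower number here means a stronger inhibitor, a higher number a weaker inhibitor. In this assay compound 1 gives > 80000 nM, a limit of the assay rather than a number (the limit of > 80000 nM in this assay, at which 1 of the 3 values shown sits). The two amides measured alongside it are compound 2 `CCC/C=C/C(=O)N(Cc1ccc(OC)c(O)c1)c1cc(OC)c(OC)c(OC)c1` and compound 3 `CC/C=C/C(=O)N(Cc1ccc(OC)c(O)c1)c1cc(OC)c(OC)c(OC)c1`; in this assay compound 2 gives 95 nM and compound 3 gives 63 nM, and a 1.5-fold lower number from compound 2 to compound 3 (0.18 log units; within the scatter). Compound 4 `COc1ccc(CNc2cc(OC)c(OC)c(OC)c2)cc1` differs from compound 1 by methoxy in place of hydrogen on an aromatic carbon. Within the data shown here, no measured step changes a methoxy on an aromatic carbon, and the step between compound 2 and compound 3 touches only a saturated chain carbon, so it gives no guide here. Compound 4 is therefore expected to show a step that the limit leaves unreadable from compound 1 to compound 4, that is, nothing beyond the scatter. The estimate for compound 4 is 100000 nM, between 30000 nM and 300000 nM.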

Compound 4, half-maximal inhibitory concentration: 18400 nM
For compound 4 the middle estimate is 5.4-fold (0.74 log units) above the measured one, and the stated range ends above it.
By their numbers in this assay, from the lowest: compounds 3 and 2 (each within the scatter of the next); then compound 4. At a limit, above all of these: compound 1.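

Among these compounds, until now no step touched this position. Here, methoxy in place of hydrogen on an aromatic carbon, para to a large group, gives an at least 4.3-fold lower number from compound 1 to compound 4 (0.63 log units; beyond the scatter) in this assay, so the position responds to this change. The full size of the step cannot be read, because compound 1 stands at a limit: the limit of > 80000 nM in this assay, at which 1 of the 4 values shown sits.

The compounds shown leave open whether an ethoxy or a fluorine at this position would give a step of similar size. They also leave open what an amine or a carboxylic acid would do there.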